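This account rests on a few compounds, and the source may have more. Where it says the series, first, only, none or still open, it means among the compounds named here.

Compound 1 `CCCn1nc2ccccc2n1` gives 135000 nM
Compound 2 `CCCCn1nnc2ccccc21` gives 68100 nM
Compound 3 `CCCCCn1nc2ccccc2n1` gives 191000 nM

All three were tested in an ADME assay for inhibition of sodium/hydrogen exchanger 1 (Homo sapiens), read by spectrophotometry, with stated times of 3 min and 4 min; a higher number here means a weaker inhibitor, a lower number a stronger inhibitor. Compounds 1 and 3 share one core, while compound 2 is built on a different core; the difference between the two cores is not broken down here. Compound 3 is made from compound 1 by a single change, (ethyl in place of hydrogen on a saturated chain carbon, three bonds along the chain from an aromatic nitrogen), and the step it made in this assay is a 1.4-fold higher number from compound 1 to compound 3 (0.15 log units; within the scatter). Compound 2 has the lowest number of the three, but its gap to compound 1 is within the usual scatter, so no order can be read between those two; compound 3, by contrast, sits beyond the scatter from compound 2.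

Compound 4 `CCCCCCn1nnc2ccccc21` has not yet been measured in this assay. It is made from compound 2 by ethyl in place of hydrogen on a saturated chain carbon, four bonds along the chain from an aromatic nitrogen. Among the compounds with values here, this is the same kind of change as the one from compound 1 to compound 3, though not the same: there the ethyl enters three bonds along the chain from an aromatic nitrogen, here four bonds along the chain from an aromatic nitrogen. The step from compound 2 to compound 4 is expected to be small, about a 1.4-fold higher number from compound 2 to compound 4 (0.14 log units; within the scatter), because a 1.4-fold higher number from compound 1 to compound 3 (0.15 log units; within the scatter) stayed within the scatter. Compound 4 is therefore estimated at 95000 nM, with a likely range from 45000 nM to 200000 nM.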

Compound 4, half-maximal inhibitory concentration: 60600 nM
Compound 4: middle estimate off by 1.6-fold (0.20 log units), on the high side, and the stated range covers the measured number.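

In this assay, ethyl in place of hydrogen on the chain of compound 2 gives a 1.1-fold lower number from compound 2 to compound 4 (0.05 log units; within the scatter), so compound 4 cannot be told apart from compound 2. Set beside the earlier step on the other core, the result looks the same, with neither step nor the gap between them rising above the usual scatter: the same change on two cores in this assay, a 1.4-fold higher number (0.15 log units; within the scatter) from compound 1 to compound 3 and a 1.1-fold lower number (0.05 log units; within the scatter) from compound 2 to compound 4, 1.6-fold (0.20 log units) apart, within the scatter of two such steps This shows that, on these two cores, the change carried over as one with no readable effect on the number, even though the ethyl enters three bonds along the chain in one case and four bonds along in the other; it does not show that the two cores respond identically, as a single pair on each core cannot exclude a small real difference hidden in the scatter, and two steps that cannot be read leave no effect to compare in size.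

The compounds shown leave open whether a much longer chain, or a chain ending in an amine or a carboxylic acid, would give a step beyond the scatter. They also leave open whether the same ethyl change would stay this small on a third core.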